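Trifluoromethyl to ethyl, with every value at a limit

The source may hold more compounds than are shown below. What is called first, only, known or untested is meant among the compounds shown, and "the series" means these compounds.

Compound 1 `CCc1cn([C@H]2C[C@H](N=[N+]=[N-])[C@@H](CO)O2)c(=O)[nH]c1=O`: > 100 ug/mL
Compound 2 `CCc1cn([C@H]2C[C@H](I)[C@@H](CO)O2)c(=O)[nH]c1=O`: > 100 ug/mL
Compound 3 `O=c1[nH]c(=O)n([C@H]2C[C@H](F)[C@@H](CO)O2)cc1C(F)(F)F`: > 100 ug/mL
Compound 4 `CCc1cn([C@H]2C[C@H](F)[C@@H](CO)O2)c(=O)[nH]c1=O`: not yet measured

In an ADME assay on Huh-7 cells (Homo sapiens) for cytotoxicity, read by XTT assay (a lower number here means that less compound is tolerated, a higher number that more compound is tolerated), compound 3 gives > 100 ug/mL, which is a limit of the assay and not a number. The other measured compounds give no sharper picture, as the whole set shares one result: the limit of > 100 ug/mL in this assay, at which 3 of the 3 values shown sit.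

Compound 4 differs from compound 3 in one group: ethyl in place of trifluoromethyl on an aromatic carbon. Among the compounds with values here, the only measured step, a step that the two limits leave unreadable from compound 1 to compound 2, has iodo in place of azido on a saturated ring carbon. It has no readable size, so it offers no guide to how large this change might be. Ethyl is not new to the set, since compound 2 also carries it. Compound 2 gives > 100 ug/mL, again a limit.

No step beyond the scatter is therefore expected in this assay, and the estimated step is a step that the limit leaves unreadable from compound 3 to compound 4. The expected value for compound 4 is 120 ug/mL, within an estimated range of 60 ug/mL to 300 ug/mL.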

Compound 4, half-maximal cytotoxic concentration: > 100 ug/mL
Compound 4: a limit, no number; the forecaster's own chance of this, stated with the estimate: 85%; the middle value does not contradict the limit.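

Compound 4 gives > 100 ug/mL, which is a limit of the assay and not a number, so its steps from compound 1, compound 2 and compound 3 cannot be read. The compounds shown leave open what concentration of any of them harms these cells, because they all share one result: the limit of > 100 ug/mL in this assay, at which 4 of the 4 values shown sit.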